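A Stereocentre Drawn S at the Assay Limit

A few compounds are considered here, and "the series" means these few. Any claim that something is new, unique, unknown or untested is made for them only; others in the source may bear on it.

In a functional assay on A549 cells (Homo sapiens) for cytotoxicity, read by MTT assay (a higher number here means a weaker inhibitor, a lower number a stronger inhibitor), compound 2 `CC1(C)C=Cc2c(C3CCc4ccc(O)cc4O3)ccc(O)c2O1` gives > 100000 nM, which is a limit and not a number. Compound 1 `CC1(C)C=Cc2c([C@H]3CCc4ccc(O)cc4O3)ccc(O)c2O1`, the form drawn R, gives > 100000 nM, also a limit. Compound 3 `CC1(C)CCc2c([C@H]3CCc4ccc(O)cc4O3)ccc(O)c2O1` gives > 100000 nM, again a limit. Compound 4 `CC1(C)C=Cc2c([C@@H]3CCc4ccc(O)cc4O3)ccc(O)c2O1` has not yet been measured. The change to it is the two compounds have the same atoms and bonds; at least one stereo element is drawn with a configuration in one of them and without one in the other: 1 of 1 stereo elements differ; a stereocentre at a saturated ring carbon is drawn without a configuration in compound 2 and S in compound 4. Going by the values given here, the one measured step that bears on this change is a step that the two limits leave unreadable from compound 1 to compound 2, which concerns (the fact that one of compounds 1 and 2 is drawn with a defined configuration and the other without, at the place where they differ). Its size cannot be read because of the limit of > 100000 nM in this assay, at which 3 of the 3 values shown sit. With no readable step to go on, no step beyond the scatter is expected in this assay, and no direction can be given. The estimated step is a number no higher from compound 2 to compound 4 (the limit leaves the size open), and it will most likely be unreadable too. Compound 4 is expected at 100000 nM, with an estimated range of 40000 nM to 200000 nM, and the assay will probably report only a limit.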

Compound 4, half-maximal inhibitory concentration: > 100000 nM
Compound 4 gave a limit, no number; the forecaster's own chance of this, stated with the estimate: 85%; the middle value sits exactly at the limit.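

In this assay compound 4 gives > 100000 nM, a limit and not a number, so neither its step from compound 2 nor its step from compound 1 can be read. The compounds shown leave open whether the configuration at this stereocentre matters at all in this assay.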